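Phenyl on the aryloxy-chain carbon in a 5-alpha-reductase series

The compounds below may be only part of what the source reports. "The series", "measured", "known", "first", "only" and "open" are said of these compounds alone.

Measured so far:
compound 1, `COc1ccccc1N1CCN(CCCOc2ccc(C(=O)Nc3ccccc3OCCCC(=O)O)cc2)CC1`, 41000 nM
compound 2, `COc1ccccc1N1CCN(CCCCOc2ccc(C(=O)Nc3ccccc3OCCCC(=O)O)cc2)CC1`, 43000 nM
compound 3, `COc1ccccc1N1CCN(CCC(Oc2ccc(C(=O)Nc3ccccc3OCCCC(=O)O)cc2)c2ccccc2)CC1`, 1000 nM

All three were run in an assay on isolated protein for inhibition of steroid 5-alpha-reductase (Rattus norvegicus); a lower number here means a stronger inhibitor, a higher number a weaker inhibitor. Compound 1 gives 41000 nM and compound 2 gives 43000 nM; these two values sit within the usual scatter of each other. The difference between the two cores of compound 1 and compound 2 is not broken down here. Compound 3 carries the core of compound 1 with one change, (phenyl in place of hydrogen on a saturated chain carbon bound to an oxygen on an aromatic ring and a saturated chain carbon), and in this assay compound 3 gives 1000 nM. The step is a 41-fold lower number from compound 1 to compound 3 (1.61 log units; beyond the scatter), which lies well beyond the scatter.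

Compound 4, `COc1ccccc1N1CCN(CCCC(Oc2ccc(C(=O)Nc3ccccc3OCCCC(=O)O)cc2)c2ccccc2)CC1`, is not yet measured. It stands to compound 2 as compound 3 stands to compound 1: the change is phenyl in place of hydrogen on a saturated chain carbon bound to an oxygen on an aromatic ring and a saturated chain carbon, the same change at the same kind of place. The expectation for compound 4 rests on one measured pair only, so it is a single-point analogy rather than a pattern. With that caveat, the step from compound 2 to compound 4 in this assay is expected to be about a 39-fold lower number from compound 2 to compound 4 (1.59 log units; beyond the scatter), because the same change gave a 41-fold lower number from compound 1 to compound 3 (1.61 log units; beyond the scatter) on the core of compound 1. On that basis compound 4 is estimated at 1100 nM, with a range from 300 nM to 4500 nM to allow for the change landing differently on the core of compound 2.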

Compound 4, half-maximal inhibitory concentration: 750 nM
Compound 4: middle estimate off by 1.5-fold (0.17 log units), on the high side, within the range that was stated.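

In this assay, phenyl in place of hydrogen on a saturated chain carbon bound to an oxygen on an aromatic ring and a saturated chain carbon again gives a large step, a 57-fold lower number from compound 2 to compound 4 (1.76 log units; beyond the scatter). Set beside the earlier step, the size of the change holds from one core to the other, and the two steps cannot be told apart: the same change on two cores in this assay, a 41-fold lower number (1.61 log units; beyond the scatter) from compound 1 to compound 3 and a 57-fold lower number (1.76 log units; beyond the scatter) from compound 2 to compound 4, 1.4-fold (0.15 log units) apart, within the scatter of two such steps. For the compounds shown here, this shows that the change carried over between these two cores in this assay, but with only two pairs it shows neither that it would carry over to any other core or assay, nor why the phenyl has this effect.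

Still open, going by these compounds, is whether the step depends on phenyl itself, or whether a methyl, benzyl or cyclohexyl group on the same carbon would give a step of similar size. Also open, on these data alone, is whether a longer chain in the core, or a tetrazole in place of the carboxylic acid, would leave the step intact.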